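From 2-chlorophenyl to 4-chlorophenyl on the shared core

The compounds below may be only part of what the source reports. "The series", "measured", "known", "first", "only" and "open" are said of these compounds alone.

In a functional assay on HT-29 cells (Homo sapiens) for inhibition, read by CCK-8 assay, with a stated time of 24 h (a higher number here means a weaker inhibitor, a lower number a stronger inhibitor), compound 3 `O=C1Nc2ccccc2/C1=C/c1ccc(-c2cn(-c3ccccc3Cl)nn2)cc1` reads > 20000 nM as a limit of the assay and not as a number. Compound 1 `O=C1Nc2ccccc2/C1=C/c1ccc(-c2cn(-c3cccc(F)c3)nn2)cc1` reads > 20000 nM as a limit too. Compound 2 `O=C1Nc2ccccc2/C1=C/c1ccc(-c2cn(-c3ccc(F)cc3)nn2)cc1` gives a number with 17700 nM as its value. Compound 4 `O=C1Nc2ccccc2/C1=C/c1ccc(-c2cn(-c3ccc(Cl)cc3)nn2)cc1` differs from compound 3 by 4-chlorophenyl in place of 2-chlorophenyl on an aromatic nitrogen with 4-chlorophenyl in place of 2-chlorophenyl on an aromatic nitrogen. The measured steps offer little: the move to 4-fluorophenyl shows an at least 1.1-fold lower number from compound 1 to compound 2 (0.05 log units; that floor lies within the scatter) and the move to 2-chlorophenyl shows an at least 1.1-fold higher number from compound 2 to compound 3 (0.05 log units; that floor lies within the scatter) while a step that the two limits leave unreadable from compound 1 to compound 3 stays unreadable. Both floors lie within the scatter, so no large change is expected in this assay here. The estimated step is an at least 1.2-fold lower number from compound 3 to compound 4 (0.09 log units; that floor lies within the scatter) and is expected to lean, if at all, toward a lower number. For compound 4 the estimate is 16000 nM with an expected range from 7000 nM to 30000 nM as its span.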

Compound 4, half-maximal inhibitory concentration: 14000 nM
Estimate against measurement, compound 4: 1.1-fold (0.06 log units) above, within the range that was stated.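

In this assay, 4-chlorophenyl in place of 2-chlorophenyl on the aromatic nitrogen gives an at least 1.4-fold lower number from compound 3 to compound 4 (0.15 log units; that floor lies within the scatter), and the comparison with the 3-fluorophenyl compound gives an at least 1.4-fold lower number from compound 1 to compound 4 (0.15 log units; that floor lies within the scatter). Chloro in place of fluoro gives a 1.3-fold lower number from compound 2 to compound 4 (0.10 log units; within the scatter), so at this position the two cannot be told apart in this assay. The first two steps are read only as floors because each starts from a limit: the limit of > 20000 nM in this assay, at which 2 of the 4 values shown sit.

Going by these compounds, it remains open whether an amine or a carboxylic acid on this phenyl ring would move the number beyond the scatter.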